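This account rests on a few compounds, and the source may have more. Where it says the series, first, only, none or still open, it means among the compounds named here.

Compound 1 `COc1cc2c(cc1OC)C(CC(=O)O)CC2` in a functional assay on the whole organism (strain Wistar) for inhibition, with Rattus norvegicus as the target, read by paw edema, with a stated time of 2 h, at a dose of 100 mg/kg (a lower number here means less inhibition, a higher number more inhibition at the dose given (going by the name of the read-out)), gives 24%.
Compound 2 `COc1cc2c(cc1OC)C(CC(=O)Nc1ccccc1C)CC2` in this assay gives 18%.
Compound 3 `COc1cc2c(cc1OC)C(CC(=O)Nc1cccc(C)c1)CC2` in this assay gives 29%.

Compound 3 holds the highest of the three numbers in this assay. Its distance from compound 1 is small, a number 5 percentage points higher from compound 1 to compound 3 (within the scatter), whereas against compound 2 the gap is real, a number 11 percentage points higher from compound 2 to compound 3 (beyond the scatter). The step from the acid to the (2-methylphenyl)amide, a number 6 percentage points lower from compound 1 to compound 2 (within the scatter), also stays within the scatter.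

Compound 4 `COc1cc2c(cc1OC)C(CC(=O)Nc1ccc(C)cc1)CC2` differs from compound 3 in one place only: 4-methylphenyl in place of 3-methylphenyl on an amide-type nitrogen. Going by the values given here, the only measured step that bears directly on this kind of change is the one between compound 2 and compound 3, in which moving the methyl from 2-methylphenyl to 3-methylphenyl on the amide-type nitrogen raised inhibition modestly, a number 11 percentage points higher from compound 2 to compound 3 (beyond the scatter). Among the compounds with values here, no measured pair shows what the 4-methylphenyl amide does; the three amide results sit around the acid, with one beyond the scatter on the low side. On that basis the account expects compound 4 to remain in the same band as compound 3, with a step of about a number 2 percentage points lower from compound 3 to compound 4 (within the scatter), that is, none clearly beyond the scatter. The estimate for compound 4 in this assay is 27%, with a range from 15% to 38%.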

Compound 4, a percentage reported as inhibition, in the whole organism at one dose (the size of the read-out at that dose, not a potency): 26%
The estimate for compound 4 lay 1 percentage points above the measured number; the measured number falls inside the stated range.
By their numbers in this assay, from the lowest: compounds 2, 1, 4 and 3 (each within the scatter of the next, the first and the last beyond it).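

Exchanging 3-methylphenyl for 4-methylphenyl on the amide-type nitrogen produces no difference that can be told apart in this assay (a number 3 percentage points lower from compound 3 to compound 4 (within the scatter)). Going by these compounds alone, the gap beyond the scatter seen on going from 2-methylphenyl to 3-methylphenyl has no counterpart with 4-methylphenyl (a number 8 percentage points higher from compound 2 to compound 4 (within the scatter)), and placing (4-methylphenyl)amino instead of hydroxy on the carbonyl carbon likewise leaves the number within the scatter of the acid (a number 2 percentage points higher from compound 1 to compound 4 (within the scatter)). No measurement at hand offers a reason for these numbers.

From the compounds shown here alone, what remains open is whether a group other than methyl on the phenyl ring, such as a chlorine atom or a methoxy group, would move the number in this assay beyond the scatter of the acid. The compounds also leave unanswered how an amide of an aliphatic amine such as piperidine, or a longer chain joining the shared core to the carbonyl, would read in this test, and how any of these amides would behave at another dose.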